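The source may report more compounds than this note shows. Statements on the series, on what has been measured and on what is new or still open speak of the compounds shown alone.

Notes on the series in a functional assay on HaCaT cells (Homo sapiens) for inhibition, read by sulforhodamine B assay, with a stated time of 48 h; on this read-out lower numbers stand for stronger inhibition of growth and higher numbers for weaker inhibition of growth. Compound 1 `COc1ccc(/C=C/C2(C)C=CC(=O)O2)c(OC)c1` gives 53600 nM. Compound 2 `COc1ccc(/C=C/C2(C)C=CC(=O)O2)cc1OC` gives 838000 nM. Compound 3 `COc1cc(/C=C/C2(C)C=CC(=O)O2)cc(OC)c1OC` gives 175000 nM. Among the compounds with values here, compound 1 and compound 2 hold the same atoms joined differently; the difference between the two cores is not broken down here, and their values show only that compound 1 stands at the lower number. From compound 2 to compound 3 the change is methoxy in place of hydrogen on an aromatic carbon, and it made a 4.8-fold lower number from compound 2 to compound 3 (0.68 log units; beyond the scatter).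

Compound 4 `COc1cc(OC)c(/C=C/C2(C)C=CC(=O)O2)c(OC)c1` awaits measurement in this assay. From compound 1 it differs by methoxy in place of hydrogen on an aromatic carbon. This is the same kind of change as that from compound 2 to compound 3, not the same: the entering methoxy of compound 4 sits ortho to a group of 9 heavy atoms and meta to two methoxy groups, whereas that of compound 3 sits ortho to a methoxy group, meta to a group of 9 heavy atoms and meta to a methoxy group. One measured step of this kind exists and its surroundings differ, so a smaller step is expected, a 1.8-fold lower number from compound 1 to compound 4 (0.25 log units; within the scatter), resting on compound 1 at 53600 nM together with a 4.8-fold lower number from compound 2 to compound 3 (0.68 log units; beyond the scatter). Compound 4 is expected near 30000 nM, between 10000 nM and 90000 nM.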

Compound 4, concentration for total growth inhibition: 458000 nM
Beside the measured number, compound 4's estimate is 15-fold (1.18 log units) below it; the whole stated range lies below it.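

In this assay, methoxy in place of hydrogen on an aromatic carbon gave an 8.5-fold higher number from compound 1 to compound 4 (0.93 log units; beyond the scatter). Set beside the earlier step on another core, the same change runs the opposite way, so in this series the step read on one core does not carry over to the other, in size or in direction: the same change on two cores in this assay, a 4.8-fold lower number (0.68 log units; beyond the scatter) from compound 2 to compound 3 and an 8.5-fold higher number (0.93 log units; beyond the scatter) from compound 1 to compound 4, 41-fold (1.61 log units) apart, beyond the scatter of two such steps

This rests on a single pair for each core, and it does not show which feature of the surroundings decides the direction; for compound 4 it shows only the outcome for a methoxy ortho to a group of 9 heavy atoms and meta to two methoxy groups.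

The aromatic substituents shown are all methoxy groups, so it remains open whether the opposite directions belong to methoxy alone or would also appear with a hydroxyl, a fluorine or an amine in the same place. Also open, from the compounds shown here alone, is whether a longer chain such as ethoxy would follow the same two courses on these cores.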